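The source may hold more compounds than are shown below. What is called first, only, known or untested is meant among the compounds shown, and "the series" means these compounds.

Within the data shown here, compound 2 `Cc1ccc(CC2CCN(CCC#Cc3ccc(N)cc3)CC2)cc1` is one of two compounds measured in an assay on isolated protein for binding affinity to Adrenergic receptor alpha-1 (Rattus norvegicus), read by radioligand binding (on this read-out higher numbers stand for weaker inhibition and lower numbers for stronger inhibition), where compound 2 gives 1200 nM. The other is compound 1 `Nc1ccc(C#CCCN2CCC(Cc3ccccc3)CC2)cc1`, which in this assay gives 1000 nM; the two values lie within the scatter of each other, and the step of a 1.2-fold higher number from compound 1 to compound 2 (0.08 log units; within the scatter) is correspondingly small. Compound 3 `Nc1ccc(C#CCCN2CCC(Cc3ccc(F)cc3)CC2)cc1` departs from compound 2 by fluoro in place of methyl on an aromatic carbon. Among the measured compounds shown here, the only measured step that bears on this position is a 1.2-fold higher number from compound 1 to compound 2 (0.08 log units; within the scatter), which shows that a change at this aromatic carbon left the number essentially where it was. On that evidence alone, a second exchange at the same carbon is expected to give no step beyond the scatter, in either direction. Compound 3 is therefore expected to give 1100 nM in this assay, within a range from 500 nM to 2500 nM. The expected step of a 1.1-fold lower number from compound 2 to compound 3 (0.04 log units; within the scatter) is accordingly estimated to be small.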

Compound 3, half-maximal inhibitory concentration: 700 nM
Estimate against measurement, compound 3: 1.6-fold (0.20 log units) above; the measured number falls inside the stated range.
By their numbers in this assay, from the lowest: compounds 3, 1 and 2 (each within the scatter of the next).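

In this assay, among these compounds, the exchange of methyl for fluoro gives a 1.7-fold lower number from compound 2 to compound 3 (0.23 log units; within the scatter) and the exchange of hydrogen for fluoro gives a 1.4-fold lower number from compound 1 to compound 3 (0.15 log units; within the scatter) at this aromatic carbon, so no step among the three compounds leaves the scatter. The earlier pair covered only hydrogen and methyl, whereas the position now also holds a halogen, and the 4-fluorobenzyl compound stays within the scatter of both the benzyl and the 4-methylbenzyl compounds. Nothing available here gives a reason for this flat result.

As far as these compounds go, it remains open whether a bulkier or charged group at the same carbon, such as trifluoromethyl, methoxy or a carboxylic acid, would move the number beyond the scatter. The compounds shown also leave open how changes elsewhere on the shared core, such as a longer chain, would read in this assay.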